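From a Six-Membered Ring to a Five-Membered One

The source may report more compounds than this note shows. Statements on the series, on what has been measured and on what is new or still open speak of the compounds shown alone.

Compound 1 `Cc1c(C)c2c(c(C)c1OC(=O)CCC(=O)O)CCC(C)(C(=O)NC1CC(C)(C)N([O])C1(C)C)O2` and compound 2 `Cc1c(C)c2c(c(C)c1OC(=O)CCC(=O)NC1CC(C)(C)N([O])C(C)(C)C1)CC[C@@](C)(CCC[C@H](C)CCC[C@H](C)CCCC(C)C)O2` were both tested in a functional assay on MCF7 cells (Homo sapiens) for cytotoxicity, read by MTT assay, with a stated time of 72 h; on this read-out higher numbers stand for weaker inhibition and lower numbers for stronger inhibition. Compound 1 gave only a limit of the assay, > 300000 nM. Compound 2 likewise gave only a limit, > 300000 nM. Compound 2 therefore stands at the same point as every other value shown (the limit of > 300000 nM in this assay, at which 2 of the 2 values shown sit). Compound 3 `Cc1c(C)c2c(c(C)c1OC(=O)CCC(=O)NC1CC(C)(C)N([O])C1(C)C)CC[C@@](C)(CCC[C@H](C)CCC[C@H](C)CCCC(C)C)O2` differs from compound 2 by a group of 10 heavy atoms (8 carbon, 1 nitrogen, 1 oxygen; one five-membered non-aromatic ring with 1 hetero atom) in place of a group of 11 heavy atoms (9 carbon, 1 nitrogen, 1 oxygen; one six-membered non-aromatic ring with 1 hetero atom), on an amide-type nitrogen. Among the compounds with values here, no measured step between compounds exists here, so the expected step in this assay is a step that the limit leaves unreadable from compound 2 to compound 3, none beyond the scatter. Compound 3 is accordingly estimated at 400000 nM, within 200000 nM to 1000000 nM, most probably again as a limit.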

Compound 3, half-maximal inhibitory concentration: 95000 nM
Compound 3: middle estimate off by 4.2-fold (0.62 log units), on the high side, outside the stated range (below it).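

In this assay, putting the five-membered non-aromatic ring in place of the six-membered one on the amide-type nitrogen gives an at least 3.1-fold lower number from compound 2 to compound 3 (0.49 log units; beyond the scatter). Within the data shown here, compound 3 thus gives the only value shown that is not a limit, so the read-out does respond to the ring carried at this place. Going by these compounds, the true size of the step remains unknown because compound 2 sits at a limit of the assay: the limit of > 300000 nM in this assay, at which 2 of the 3 values shown sit.

On these data alone, how a seven-membered ring or a plain tert-butyl group on that nitrogen would read remains open. So does whether ring size alone accounts for the step, since a single pair cannot separate it from the other features of the two rings.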